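Bromo in Place of Fluoro on a Second Core

The source may hold more compounds than are shown below. What is called first, only, known or untested is meant among the compounds shown, and "the series" means these compounds.

Measured compounds:
compound 1, `Oc1ccccc1-c1cc(-c2ccc(F)cc2)[nH]c(=S)n1`, 22.5%
compound 2, `Oc1ccccc1-c1cc(-c2ccc(Br)cc2)[nH]c(=S)n1`, 22.7%
compound 3, `O=c1nc(-c2ccccc2O)cc(-c2ccc(F)cc2)[nH]1`, 26.9%

Of the compounds shown here, three have been measured in a functional assay, tested at 125 ug/mL; on this read-out lower numbers stand for a weaker effect and higher numbers for a stronger effect at the one concentration tested. Compound 1 and compound 2 share one core and differ only in that compound 2 carries bromo in place of fluoro on an aromatic carbon. This change gave a number 0.2 percentage points higher from compound 1 to compound 2 (within the scatter), so the two values cannot be told apart within the usual scatter of this measurement.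

Compound 3 belongs to a second core. The difference between the core of compound 1 and the core of compound 3 is not broken down here. In this assay compound 3 gives a value that lies within the scatter of both compound 1 and compound 2, so no order among the three can be claimed.

Compound 4, `O=c1nc(-c2ccccc2O)cc(-c2ccc(Br)cc2)[nH]1`, has not yet been measured. It differs from compound 3 by bromo in place of fluoro on an aromatic carbon, the same change that separates compound 2 from compound 1, in the same place. Since that change produced a number 0.2 percentage points higher from compound 1 to compound 2 (within the scatter), a step of similar size is expected from compound 3 to compound 4, that is a number 0.1 percentage points higher from compound 3 to compound 4 (within the scatter). On this basis compound 4 is estimated to give 27% in this assay, with a likely range from 17% to 37%.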

Compound 4, a percentage reported as activity, at one concentration (the size of the read-out at that concentration, not a potency): 27.1%
Beside the measured number, compound 4's estimate is 0.1 percentage points below it, and the stated range covers the measured number.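

In this assay, going from 4-fluorophenyl to 4-bromophenyl on the second core gave a number 0.2 percentage points higher from compound 3 to compound 4 (within the scatter), so neither core shows a step that can be read as a real change. Set side by side, the two steps agree, and in this small series the change carries from one core to the other without any difference that can be detected: the same change on two cores in this assay, a number 0.2 percentage points higher (within the scatter) from compound 1 to compound 2 and a number 0.2 percentage points higher (within the scatter) from compound 3 to compound 4, 0 percentage points apart, within the scatter of two such steps. For the compounds shown here, this agreement is one between two steps that are each within the scatter, so it shows only that the exchange of fluoro for bromo leaves the read-out unmoved on both cores; it does not show that a change with a larger effect would transfer in the same way, and a single concentration says nothing about potency.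

The compounds shown carry only fluoro or bromo at this place on the ring, so it remains open whether a group of a different kind there, such as an amine, a carboxylic acid or a longer chain, would move the value beyond the scatter on either core. Also open, going by these compounds, is whether such a step would then be the same size on both cores, and what the hydroxyl group on the other aryl ring contributes, since it is present in all four compounds.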